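Pentyl for Cyclohexyl on the Ether Oxygen of Compound 2

The source may report more compounds than this note shows. Statements on the series, on what has been measured and on what is new or still open speak of the compounds shown alone.

Compound 1 `COc1ccc2c(c1)[n+]([O-])nc(NCOC(C)c1ccccc1)[n+]2[O-]` gives 220 nM.
Compound 2 `[O-][n+]1nc(NCOC2CCCCC2)[n+]([O-])c2ccccc21` gives 4390 nM.
Compound 3 `COc1ccc2c(c1)[n+]([O-])nc(NCOCc1ccccc1)[n+]2[O-]` gives 2400 nM.

In a functional assay on KB cells (Homo sapiens) for cytotoxicity, read by MTT assay, with a stated time of 72 h (on this read-out lower numbers stand for stronger inhibition and higher numbers for weaker inhibition), compound 2 stands at the highest of the three numbers; compound 3 is within the scatter of it, while compound 1 lies far below it. Compound 4 `CCCCCOCNc1n[n+]([O-])c2ccccc2[n+]1[O-]` differs from compound 2 by pentyl in place of cyclohexyl on an oxygen on a saturated carbon. Among the measured compounds shown here, the only measured step, an 11-fold higher number from compound 1 to compound 3 (1.04 log units; beyond the scatter), concerns a different place in the molecule and a different pair of compounds, so no measured step bears on the change from compound 2 to compound 4. For that reason the step is expected to be a 1.1-fold lower number from compound 2 to compound 4 (0.04 log units; within the scatter), nothing beyond the scatter in either direction. Compound 4 is therefore estimated at 4000 nM, with a range from 1500 nM to 12000 nM.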

Compound 4, half-maximal inhibitory concentration: 1220 nM
Estimate against measurement, compound 4: 3.3-fold (0.52 log units) above; measured number outside the range, below it.
By their numbers in this assay, from the lowest: compound 1; then compounds 4, 3 and 2 (each within the scatter of the next, the first and the last beyond it).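

In this assay the group on this oxygen proves to count by itself: pentyl in place of cyclohexyl gives a 3.6-fold lower number from compound 2 to compound 4 (0.56 log units; beyond the scatter) on an unchanged core. Among the compounds shown here, the one earlier step lay at a different place and on a different core, so this is the first reading at this position. The ring of compound 2 is not required here, since the open chain of compound 4 gives the lower number.

Going by these compounds, whether a longer chain or an amine on this oxygen would lower the number further remains open, as does whether pentyl acts alike on the core of compound 1. Nothing measured here explains the step.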